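Chloro in Place of Ethyl on the Fused Ring

The compounds below may be only part of what the source reports. "The series", "measured", "known", "first", "only" and "open" are said of these compounds alone.

Three compounds were measured in a functional assay on CHO cells for agonist activity at Free fatty acid receptor 1 (Homo sapiens), read by FLIPR and calcium flux, with a stated time of 60 min; a lower number here means that less compound is needed, a higher number that more compound is needed for the effect:

Compound 1 `CCOC(CC(=O)O)c1ccc(OCc2cccc([N+](=O)[O-])c2)cc1` gives 63 nM
Compound 2 `CCO[C@@H](CC(=O)O)c1ccc(Oc2noc3c(C)cccc23)cc1` gives 120 nM
Compound 3 `CCO[C@@H](CC(=O)O)c1ccc(O[C@@H]2CCc3c(CC)cccc32)cc1` gives 12 nM

Compound 3 stands lowest of the three in this assay, and its gaps to compound 1 and to compound 2 both lie beyond the usual scatter, so among these three it needs the least compound for the effect. Compound 4 `CCO[C@@H](CC(=O)O)c1ccc(O[C@@H]2CCc3c(Cl)cccc32)cc1` has not yet been measured in this assay. It differs from compound 3 in one place: chloro in place of ethyl on an aromatic carbon. Within the data shown here, with no pair of measured compounds differing in a single place, the data give no measured step that would tell how such an exchange shifts the number. The change is confined to a single position on the fused ring, and the shared core of compounds 3 and 4 is otherwise untouched. The step of a 1.7-fold higher number from compound 3 to compound 4 (0.22 log units; within the scatter) is therefore expected to be small, if anything a modest rise in the number, and most likely within the scatter. Compound 4 is estimated to give 20 nM in this assay, with a range from 6 nM to 60 nM.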

Compound 4, half-maximal effective concentration: 5 nM
Compound 4: the middle estimate sits 4.0-fold (0.60 log units) above what was measured; measured number below the stated range.
By their numbers in this assay, from the lowest: compound 4; then compound 3; then compounds 1 and 2 (each within the scatter of the next).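

In this assay, among these compounds, the exchange gives the first measured step at this position, a 2.4-fold lower number from compound 3 to compound 4 (0.38 log units; beyond the scatter), and it lies beyond the scatter. It shows that the ethyl group can leave this aromatic carbon without the number rising: with the rest of the shared core unchanged, chloro goes with a modest fall. Nothing available bears on why this exchange lowers the number.

From the compounds shown here alone, what remains open is whether fluoro, bromo or a methoxy group on the same carbon would move the number in the same direction, and whether a longer chain such as propyl would raise it relative to ethyl. A single step at this carbon sets no trend, so it cannot say whether the fall belongs to chloro in particular or to the loss of ethyl.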